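A few compounds are considered here, and "the series" means these few. Any claim that something is new, unique, unknown or untested is made for them only; others in the source may bear on it.

Measured compounds:
Compound 1, `O=C(CN(c1nc(Cl)nc2[nH]cnc12)C1CC1)NCC(=O)OCc1ccccc1`: in a functional assay on the whole organism (Tail, strain ICR) with Mus musculus as the target, in the tail flick test, with a stated time of 150 min, at a dose of 6.25 umol/kg by the oral route (a lower number here means a weaker effect, a higher number a stronger effect of the compound at the dose given), compound 1 gives 3.47%.
Compound 2, `CC(C)[C@H](NC(=O)CN(c1nc(Cl)nc2[nH]cnc12)C1CC1)C(=O)OCc1ccccc1`: in this assay compound 2 gives 3.07%.

Both measured compounds share one core and differ only at one saturated chain carbon. Compound 2 stands alongside compound 1 on the numbers shown: the change a number 0.4 percentage points lower from compound 1 to compound 2 (within the scatter), and the two values therefore cannot be told apart. Neither compound shows a marked effect at the dose given.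

Compound 3, `NCCCC[C@H](NC(=O)CN(c1nc(Cl)nc2[nH]cnc12)C1CC1)C(=O)OCc1ccccc1`, differs from compound 2 as follows:
4-aminobutyl in place of isopropyl on a saturated chain carbon bound to an amide-type nitrogen and a carbonyl carbon

Among the measured compounds shown here, only one measured step bears on this change, the one from compound 1 to compound 2, and it stayed within the scatter. That step put a small branched group where hydrogen had been; the change to compound 3 is larger, replacing isopropyl with 4-aminobutyl, and nothing measured here tracks such an exchange. The account therefore rests on the two values seen so far, both near the floor of the read-out. Compound 3 is estimated to give 4%, within a range of 0% to 12%. The step this estimate means, a number 0.9 percentage points higher from compound 2 to compound 3 (within the scatter), is expected to lie within the scatter.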

Compound 3, a percentage reported as activity, at one dose (the size of the read-out at that dose, not a potency): 4.87%
Estimate against measurement, compound 3: 0.9 percentage points below, within the range that was stated.
By their numbers in this assay, from the lowest: compounds 2, 1 and 3 (each within the scatter of the next).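

At the saturated chain carbon bound to an amide-type nitrogen and a carbonyl carbon, 4-aminobutyl brings in a longer chain ending in an amine, yet in this assay the exchange for isopropyl gives a number 1.8 percentage points higher from compound 2 to compound 3 (within the scatter) and the exchange for hydrogen gives a number 1.4 percentage points higher from compound 1 to compound 3 (within the scatter) and so neither step can be told from the scatter. This position has now carried hydrogen, a small branched group and a longer chain with an amine, and the three compounds cannot be set apart, with none showing a marked effect at the dose given. No accompanying measurement helps to interpret these numbers.

Going by these compounds, whether a carboxylic acid, a phenyl ring or a shorter chain with an amine at this carbon would give a read-out beyond the scatter remains open. The compounds shown also leave open whether the response would differ at another dose or time, or with a free carboxylic acid in place of the benzyl ester, which all three compounds share.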